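Ethyl for chloro on the phenoxy arm of compound 1

This account rests on a few compounds, and the source may have more. Where it says the series, first, only, none or still open, it means among the compounds named here.

Measured compounds:
- compound 1 `O=C(O)CCc1ccc(NC(=O)c2nnc(COc3cccc(Cl)c3)s2)cc1`: 1570 nM
- compound 2 `Cc1cccc(OCc2nnc(C(=O)Nc3ccc(CCC(=O)O)cc3)s2)c1`: 3260 nM

In a functional assay on CHO cells for agonist activity at Free fatty acid receptor 1 (Homo sapiens), read by FLIPR and calcium flux, tested at 1 uM (on this read-out higher numbers stand for an effect only at larger amounts of compound and lower numbers for an effect already at smaller amounts), compound 1 gives 1570 nM, the lowest of the two numbers. Among the compounds with values here, compound 2 stands nearest to it: the single change of methyl in place of chloro on an aromatic carbon gives a 2.1-fold higher number from compound 1 to compound 2 (0.32 log units; beyond the scatter).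

Compound 3 `CCc1ccc(OCc2nnc(C(=O)Nc3ccc(CCC(=O)O)cc3)s2)cc1` is the next step from compound 1. The change is 4-ethylphenyl in place of 3-chlorophenyl on an oxygen on a saturated carbon. Within the data shown here, only one measured step bears on it, the one from compound 1 to compound 2, which shows that replacing the chloro by a small alkyl group on this ring raised the number modestly. Among the measured compounds shown here, the ethyl in compound 3 sits at a different place on the ring, and no measured pair tests that place, so the expectation rests loosely on the one step. Compound 3 is therefore expected to show a modestly higher number than compound 1, roughly a 1.8-fold higher number from compound 1 to compound 3 (0.25 log units; within the scatter), with wide uncertainty. The estimate for compound 3 in this assay is 2800 nM, within a range from 1000 nM to 8000 nM.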

Compound 3, half-maximal effective concentration: 1170 nM
Estimate against measurement, compound 3: 2.4-fold (0.38 log units) above; the range from low to high includes it.
By their numbers in this assay, from the lowest: compounds 3 and 1 (each within the scatter of the next); then compound 2.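

In this assay, putting 4-ethylphenyl in place of 3-chlorophenyl on the oxygen gives a 1.3-fold lower number from compound 1 to compound 3 (0.13 log units; within the scatter), so among these three compounds a chlorine on this ring is not required to reach the level of compound 1. The step from the methyl compound adds more, with a 2.8-fold lower number from compound 2 to compound 3 (0.45 log units; beyond the scatter): carrying a small alkyl group instead of chloro does not by itself go with the higher number of compound 2, as compound 3 also carries one and does not show that number. Because 4-ethylphenyl differs from 3-methylphenyl in both the alkyl group and its place on the ring, this step cannot say which of the two differences matters.

The three compounds therefore leave the effect of the group and the effect of its place on the ring unseparated. Going by these compounds, it also remains open how a propyl chain, a methoxy group or an amine on this ring would read out in this assay. Nothing given here offers an explanation for these differences.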